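Hydroxy for chloro on the pendant ring of compound 2

The compounds below may be only part of what the source reports. "The series", "measured", "known", "first", "only" and "open" are said of these compounds alone.

Two octylsulfonamide benzoic acids have been measured in an assay on mitochondria (strain BALB/c) for inhibition of glycerol-3-phosphate acyltransferase 1, mitochondrial (Mus musculus), read by scintillation counting, with a stated time of 10 min; a higher number here means a weaker inhibitor, a lower number a stronger inhibitor. Compound 1 `CCCCCCCCS(=O)(=O)Nc1cc(-c2ccccc2F)ccc1C(=O)O` gives 47200 nM in this assay, and compound 2 `CCCCCCCCS(=O)(=O)Nc1ccc(-c2ccccc2Cl)cc1C(=O)O` gives 14400 nM, the lower of the two numbers and beyond the scatter from compound 1. Compound 3 `CCCCCCCCS(=O)(=O)Nc1ccc(-c2ccccc2O)cc1C(=O)O` is the unmeasured partner of compound 2, differing by hydroxy in place of chloro on an aromatic carbon. Among the compounds with values here, no measured pair shows this change, so its size is open; the step is expected to be small, toward a higher number, and possibly within the scatter, as a 1.5-fold higher number from compound 2 to compound 3 (0.18 log units; within the scatter). Compound 3 is therefore estimated at 22000 nM in this assay, within 7000 nM to 65000 nM.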

Compound 3, half-maximal inhibitory concentration: 61700 nM
Compound 3: the middle estimate sits 2.8-fold (0.45 log units) below what was measured; measured number inside the range.
By their numbers in this assay, from the lowest: compound 2; then compounds 1 and 3 (each within the scatter of the next).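

In this assay, within the data shown here, the change from 2-chlorophenyl to 2-hydroxyphenyl gives the first comparison of compounds that differ in one place, and it costs activity (a 4.3-fold higher number from compound 2 to compound 3 (0.63 log units; beyond the scatter)). At this position, therefore, the hydrogen-bond donor and acceptor that enter with hydroxy bring no gain over chloro, and the step is modest but beyond the scatter. No evidence at hand accounts for the step. The compounds shown leave open how an amine or a methoxy group would read at this position. They also leave open whether a longer chain in place of octyl would change the number.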